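This account rests on a few compounds, and the source may have more. Where it says the series, first, only, none or still open, it means among the compounds named here.

Compound 1 `CCc1ccnc(C(=O)Nc2nn[nH]n2)c1`: 29%
Compound 2 `O=C(Nc1nn[nH]n1)c1cc(Br)ccn1`: 34%
Compound 3 `Cc1ccnc(C(=O)Nc2nn[nH]n2)c1`: 42%

In a functional assay on the whole organism for inhibition, with Rattus norvegicus as the target, at a dose of 3 mg/kg by the oral route (on this read-out higher numbers stand for a stronger effect at the one dose given and lower numbers for a weaker effect), compound 3 carries the largest of the three numbers, yet the nearest step to it, a number 8 percentage points higher from compound 2 to compound 3 (within the scatter), is within the scatter, and it stands clear only through a number 13 percentage points higher from compound 1 to compound 3 (beyond the scatter). Compound 4 `O=C(Nc1nn[nH]n1)c1cc(Cl)ccn1` has not been measured. Its change from compound 3 is chloro in place of methyl on an aromatic carbon. Among the measured compounds shown here, the steps that bear on a halogen at this ring carbon are a number 5 percentage points higher from compound 1 to compound 2 (within the scatter) and a number 8 percentage points higher from compound 2 to compound 3 (within the scatter), both within the scatter, so for compound 4 the expected step is a number 6 percentage points lower from compound 3 to compound 4 (within the scatter), nothing beyond the scatter. The estimate for compound 4 in this assay is 36%, with a range from 24% to 48%.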

Compound 4, a percentage reported as inhibition, in the whole organism at one dose (the size of the read-out at that dose, not a potency): 72%
Estimate against measurement, compound 4: 36 percentage points below; measured number outside the range, above it.
By their numbers in this assay, from the lowest: compounds 1, 2 and 3 (each within the scatter of the next, the first and the last beyond it); then compound 4.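

At the ring carbon opposite the ring nitrogen, chloro separates from the other three groups in this assay: a number 30 percentage points higher from compound 3 to compound 4 (beyond the scatter), a number 38 percentage points higher from compound 2 to compound 4 (beyond the scatter) and a number 43 percentage points higher from compound 1 to compound 4 (beyond the scatter). The bromo to chloro change shows that a halogen at this carbon does not by itself give the higher number, so the identity of the halogen matters here. Nothing available accounts for this result.

Still open, going by these compounds, is whether fluoro, iodo or an amine at this carbon would match chloro. Also open, on these data alone, is whether chloro would hold its number on another ring carbon.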